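From octyl to isopropyl in compound 1

The source may hold more compounds than are shown below. What is called first, only, known or untested is meant among the compounds shown, and "the series" means these compounds.

In a functional assay on the whole organism for inhibition, with Cavia porcellus as the target, with a stated time of 2 h (on this read-out higher numbers stand for an effect only at larger amounts of compound and lower numbers for an effect already at smaller amounts), compound 1 `CCCCCCCC/C(=C\C=C\C(=O)N[C@H](C)CCCc1cccnc1)c1ccc(OC)cc1` gives 13 mg/kg. In this assay compound 2 `Cc1ccc(C(=C/C=C/C(=O)N[C@H](C)CCCc2cccnc2)c2ccc(C)cc2)cc1` gives 18 mg/kg, within the scatter of compound 1. In this assay compound 3 `COc1ccc(C(=C/C=C/C(=O)N[C@@H](CCCc2cccnc2)C2CC2)c2ccc(OC)cc2)cc1` gives 6 mg/kg, a lower number than compound 1 and beyond the scatter. Compound 1 therefore sits at the upper end of the three numbers, level with compound 2 within the scatter.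

Compound 4 `COc1ccc(/C(=C/C=C/C(=O)N[C@H](C)CCCc2cccnc2)C(C)C)cc1` has not yet been measured. It differs from compound 1 at one place: isopropyl in place of octyl on a double-bonded chain carbon bound to an aromatic carbon and a double-bonded chain carbon, with isopropyl in place of octyl on a double-bonded chain carbon bound to an aromatic carbon and a double-bonded chain carbon.

For the measured compounds named here, no two measured compounds differ at only one place, so this change has no direct precedent. Compound 2 at 18 mg/kg carries a different group on that carbon from compound 1 at 13 mg/kg, yet the two lie within the scatter. No step beyond the scatter is therefore expected in this assay, in either direction. The expected size is a 1.1-fold lower number from compound 1 to compound 4 (0.03 log units; within the scatter). Compound 4 is expected at 12 mg/kg, with an estimated range of 4 mg/kg to 35 mg/kg.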

Compound 4, dose for 50% inhibition: 30 mg/kg
Beside the measured number, compound 4's estimate is 2.5-fold (0.40 log units) below it, within the range that was stated.
By their numbers in this assay, from the lowest: compound 3; then compounds 1, 2 and 4 (each within the scatter of the next, the first and the last beyond it).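

For the compounds shown here, replacing octyl with isopropyl on a double-bonded chain carbon bound to an aromatic carbon and a double-bonded chain carbon gives the first step that changes one place only: in this assay it gives a 2.3-fold higher number from compound 1 to compound 4 (0.36 log units; beyond the scatter) and so counts as a modest change. This position is therefore not silent, since this one change moves the number beyond the scatter, towards a larger dose for the same effect. No measurement at hand accounts for this step.

As far as these compounds go, one step cannot tell chain length from branching, so it stays open how a straight propyl chain or a hexyl chain at this place would compare with octyl and isopropyl. From the compounds shown here alone, it also stays open whether this place tolerates a chain ending in an amine or a carboxylic acid.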